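The source may report more compounds than this note shows. Statements on the series, on what has been measured and on what is new or still open speak of the compounds shown alone.

Series notes toward compound 4. Three members have been measured in an ADME assay on microsomes from liver (Homo sapiens) for metabolic stability, tested at 2.5 uM; a higher number here means faster removal of the compound, a lower number slower removal. Compound 1 `O=S(=O)(c1ccc(F)c(Cl)c1)c1cnc2c(F)cccc2c1-c1cccc(Cl)c1` gives 0.18 mL/min, compound 2 `O=S(=O)(c1cc(F)cc(F)c1)c1cnc2c(F)cccc2c1-c1cccc(Cl)c1` gives 0.64 mL/min, and compound 3 `N#Cc1cccc(S(=O)(=O)c2cnc3c(F)cccc3c2-c2cccc(Cl)c2)c1` gives 1.11 mL/min. Compound 1 stands lowest of the three: a 3.6-fold higher number from compound 1 to compound 2 (0.55 log units; beyond the scatter) and a 6.2-fold higher number from compound 1 to compound 3 (0.79 log units; beyond the scatter), both modest but beyond the scatter, while a 1.7-fold higher number from compound 2 to compound 3 (0.24 log units; within the scatter) lies within the scatter. Both steps away from compound 1 alter the group on the sulfonyl sulfur and leave the rest untouched.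

Compound 4 `O=S(=O)(c1ccc(F)c(Cl)c1)c1cnc2c(F)cccc2c1-c1cccc(F)c1` differs from compound 1 at a different site: fluoro in place of chloro on an aromatic carbon. Among the measured compounds shown here, no measured pair varies this ring, so the measured steps bear on it only indirectly, showing that the shifts seen so far, all modest, came from exchanging the group on the sulfonyl sulfur. In this assay compound 4 is therefore expected to sit close to compound 1, with a 1.4-fold higher number from compound 1 to compound 4 (0.14 log units; within the scatter) and no step beyond the scatter. The estimate for compound 4 is 0.25 mL/min, with a range from 0.1 mL/min to 0.6 mL/min.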

Compound 4, intrinsic clearance in a liver preparation (reported as CLH), per the amount of preparation that the assay uses: 1.23 mL/min
Beside the measured number, compound 4's estimate is 4.9-fold (0.69 log units) below it; the measured number lies above the stated range.
By their numbers in this assay, from the lowest: compound 1; then compounds 2, 3 and 4 (each within the scatter of the next).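

The 3-chlorophenyl ring is a sensitive position: exchanging one halogen for another, with one heavy atom leaving and one entering and no change in ring count, hydrogen-bond donors, hydrogen-bond acceptors or net charge, gives a 6.8-fold higher number from compound 1 to compound 4 (0.83 log units; beyond the scatter) in this assay. Changes beyond the scatter are therefore not confined to the group on the sulfonyl sulfur, as the earlier steps alone might have suggested, and 3-chlorophenyl to 3-fluorophenyl cannot be treated as a neutral swap in this series. Nothing shown here explains why this single-atom exchange moves the number so far.

This exchange is shown only with the 3-chloro-4-fluorophenyl group on the sulfonyl sulfur, so whether it carries over to the groups of compound 2 and compound 3 remains open. Also open, going by these compounds, is where a methoxy group, a methyl group or a plain hydrogen in place of the chloro would fall in this assay.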